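Acylating the amine: a small cyclopropyl carbonyl tested

The compounds below may be only part of what the source reports. "The series", "measured", "known", "first", "only" and "open" are said of these compounds alone.

Compound 1: `COc1ccccc1C(=O)Nc1nc(-c2ccccc2)nc2c1nnn2Cc1ccccc1`, 1520 nM
Compound 2: `O=C(Nc1nc(-c2ccccc2)nc2c1nnn2Cc1ccccc1)c1ccoc1`, 10 nM
Compound 3: `Nc1nc(-c2ccccc2)nc2c1nnn2Cc1ccccc1`, 5.6 nM

Three compounds share one core and differ only at a nitrogen on an aromatic ring. In an assay (strain Wistar) for displacement of a labelled ligand from adenosine receptor A1 (Rattus norvegicus), read by scintillation counting (a lower number here means a stronger inhibitor, a higher number a weaker inhibitor), compound 3 gives 5.6 nM, the lowest of the three numbers. Its nearest neighbour is compound 2, with 10 nM; the step of a 1.8-fold lower number from compound 2 to compound 3 (0.25 log units; within the scatter) lies within the scatter, so the two cannot be ordered. Compound 1, with 1520 nM, stands far apart: the step of a 270-fold lower number from compound 1 to compound 3 (2.43 log units; beyond the scatter) is large, as is a 150-fold lower number from compound 1 to compound 2 (2.18 log units; beyond the scatter).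

Compound 4, `O=C(Nc1nc(-c2ccccc2)nc2c1nnn2Cc1ccccc1)C1CC1`, is not yet measured. It differs from compound 3 by cyclopropylcarbonyl in place of hydrogen on a nitrogen on an aromatic ring, that is, amino to (cyclopropylcarbonyl)amino. The two acyl steps recorded point in opposite ways: the (furan-3-yl)carbonyl group leaves the number essentially unchanged, while the (2-methoxyphenyl)carbonyl group raises it greatly. The cyclopropylcarbonyl group, with only five heavy atoms and no aromatic ring, is closer in size to the furan-3-yl case than to the 2-methoxyphenyl case, so the step of a 2.1-fold higher number from compound 3 to compound 4 (0.33 log units; beyond the scatter) is expected to stay within the scatter or rise only modestly. Compound 4 is therefore estimated at 12 nM, within 4 nM to 45 nM.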

Compound 4, inhibition constant: 7.5 nM
For compound 4 the middle estimate is 1.6-fold (0.20 log units) above the measured one; the measured number falls inside the stated range.
By their numbers in this assay, from the lowest: compounds 3, 4 and 2 (each within the scatter of the next); then compound 1.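

In this assay, a second acyl group on this nitrogen stays level with the free amine (a 1.3-fold higher number from compound 3 to compound 4 (0.13 log units; within the scatter)), and the cyclopropylcarbonyl group has no aromatic ring, so an aromatic ring on the carbonyl carbon is not required to keep the number this low. Cyclopropyl and furan-3-yl on the carbonyl carbon cannot be told apart (a 1.3-fold lower number from compound 2 to compound 4 (0.12 log units; within the scatter)). Within the data shown here, compound 1 is now the one acylated compound of three that stands apart (a 200-fold lower number from compound 1 to compound 4 (2.31 log units; beyond the scatter)), which ties its high number to the 2-methoxyphenyl group and not to acylation of this nitrogen as such.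

The compounds leave open whether a plain phenylcarbonyl or a larger cyclohexylcarbonyl group would stay at this level, and so whether the methoxy group or the size of the acyl group separates compound 1 from the others. Nothing shown gives a reason for these results.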